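The compounds below may be only part of what the source reports. "The series", "measured", "known", "first", "only" and "open" are said of these compounds alone.

Compound 1 `CN(C)CCNc1ccnc2cc(OCc3ccccc3)ccc12`: 2350 nM
Compound 2 `CCCCCCOc1ccc2c(Cl)ccnc2c1`: > 10000 nM

In a functional assay on SK-OV-3 cells (Homo sapiens) for cytotoxicity, read by MTT assay, with a stated time of 48 h (on this read-out lower numbers stand for stronger inhibition and higher numbers for weaker inhibition), compound 2 gives > 10000 nM, which is a limit of the assay rather than a number. Compound 3 `Clc1ccnc2cc(OCc3ccccc3)ccc12` differs from compound 2 by phenyl in place of pentyl on a saturated chain carbon bound to an oxygen on an aromatic ring. Among the measured compounds shown here, no measured pair shows the effect of this change on its own. Compound 2 sits at the limit of > 10000 nM in this assay, at which 1 of the 2 values shown sits. Compound 1 carries the same phenyl group with a different substituent on the shared core and gives 2350 nM. Only a modest step is expected, a step that the limit leaves unreadable from compound 2 to compound 3, not clearly beyond the scatter. Compound 3 is estimated at 15000 nM, within 4000 nM to 60000 nM.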

Compound 3, half-maximal inhibitory concentration: 5170 nM
Compound 3: middle estimate off by 2.9-fold (0.46 log units), on the high side; low and high end bracket the measured number.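

Phenyl in place of pentyl on a saturated chain carbon bound to an oxygen on an aromatic ring gives an at least 1.9-fold lower number from compound 2 to compound 3 (0.28 log units; that floor lies within the scatter) and so provides a first number for the chloro compounds. That step can be read only as a floor because compound 2 sits at a limit: the limit of > 10000 nM in this assay, at which 1 of the 3 values shown sits. At the other changing place, chloro in place of (2-(dimethylamino)ethyl)amino on an aromatic carbon gives a 2.2-fold higher number from compound 1 to compound 3 (0.34 log units; beyond the scatter) with the phenyl group kept. The compounds shown leave open how a carboxylic acid or a longer chain would compare at the phenyl place.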